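Taking the hydroxyl groups off compound 2

The compounds below may be only part of what the source reports. "The series", "measured", "known", "first", "only" and "open" are said of these compounds alone.

The compounds below were measured in a functional assay on MCF7 cells (Homo sapiens) for antiproliferative activity, read by MTT assay, with a stated time of 72 h (on this read-out lower numbers stand for stronger inhibition and higher numbers for weaker inhibition), as follows:
Compound 1 `COc1cc(/C=C/c2ccc(C3=C(c4ccc(O)cc4)C4CC(S(=O)(=O)Oc5ccccc5)C3O4)cc2)cc(OC)c1` gives > 100000 nM as a limit of the assay, not a number
Compound 2 `O=S(=O)(Oc1ccccc1)C1CC2OC1C(c1ccc(/C=C/c3cc(O)cc(O)c3)cc1)=C2c1ccc(O)cc1` gives 20100 nM
Compound 3 `O=S(=O)(Oc1cccc(C(F)(F)F)c1)C1CC2OC1C(c1ccc(/C=C/c3cc(O)cc(O)c3)cc1)=C2c1ccc(O)cc1` gives 11500 nM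

Among the measured compounds shown here, compound 2 at 20100 nM lies within the scatter of compound 3 at 11500 nM and these two are the only true numbers so far. The step of a 1.7-fold lower number from compound 2 to compound 3 (0.24 log units; within the scatter) is a change elsewhere in the molecule and offers little guidance here. Compound 4 `O=S(=O)(Oc1ccccc1)C1CC2OC1C(c1ccc(/C=C/c3ccccc3)cc1)=C2c1ccc(O)cc1` carries phenyl in place of 3,5-dihydroxyphenyl on a double-bonded chain carbon bound to a double-bonded chain carbon, and the full count reads phenyl in place of 3,5-dihydroxyphenyl on a double-bonded chain carbon bound to a double-bonded chain carbon for this change. For the measured compounds named here, the one measured step at this place is an at least 4.9-fold lower number from compound 1 to compound 2 (0.69 log units; beyond the scatter) and it lies beyond the scatter. Going by the values given here, compound 4 shares with compound 1 the lack of the hydroxyl groups of compound 2, though no measured step goes to plain phenyl. A higher number is therefore expected in this assay for this change. The expected step is a 2.5-fold higher number from compound 2 to compound 4 (0.40 log units; beyond the scatter) on this reasoning. Compound 4 is estimated at 50000 nM with an expected range from 20000 nM to 100000 nM as the upper end.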

Compound 4, half-maximal inhibitory concentration: 25200 nM
For compound 4 the middle estimate is 2.0-fold (0.30 log units) above the measured one; the measured number falls inside the stated range.
By their numbers in this assay, from the lowest: compounds 3, 2 and 4 (each within the scatter of the next, the first and the last beyond it). At a limit, above all of these: compound 1.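

In this assay, the hydroxyl groups turn out not to be what sets the number at this position, since plain phenyl in place of 3,5-dihydroxyphenyl stays within the scatter (a 1.3-fold higher number from compound 2 to compound 4 (0.10 log units; within the scatter)). The gain first read from the methoxy-to-hydroxyl step is therefore seen again on simply dropping the methoxy groups (an at least 3.9-fold lower number from compound 1 to compound 4 (0.59 log units; beyond the scatter)), so among these compounds it is the 3,5-dimethoxyphenyl of compound 1 that goes with the poor result, not the absence of hydroxyl groups. Compound 1 itself stands at a limit of the assay, not a number, so both steps from it are bounds only: the limit of > 100000 nM in this assay, at which 1 of the 4 values shown sits.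

The compounds shown leave open how an amine or a carboxylic acid on this ring would read. On these data alone, it also remains open whether a single methoxy group is enough to raise the number as the pair of them does in compound 1.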